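This account rests on a few compounds, and the source may have more. Where it says the series, first, only, none or still open, it means among the compounds named here.

Measured so far:
compound 1 `Fc1cccc(-c2nc(Nc3ccccc3)c3cc(F)ccc3n2)c1` — 45500 nM
compound 2 `COc1ccc(Nc2nc(-c3cccc(F)c3)nc3ccc(F)cc23)cc1` — 41100 nM
compound 3 `Fc1cccc(-c2nc(Nc3ccccc3Cl)c3cc(F)ccc3n2)c1` — a limit only, > 50000 nM

In a functional assay on U-937 cells (Homo sapiens) for cytotoxicity, read by MTT assay, with a stated time of 48 h (on this read-out lower numbers stand for stronger inhibition and higher numbers for weaker inhibition), compound 1 gives 45500 nM, the highest of the two numbers recorded; compound 2 sits nearest, and a 1.1-fold lower number from compound 1 to compound 2 (0.04 log units; within the scatter) lies within the scatter. Compound 3 reports no number in this assay but only a limit (the limit of > 50000 nM in this assay, at which 1 of the 3 values shown sits).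

Compound 4 `Cc1ccc(Nc2nc(-c3cccc(F)c3)nc3ccc(F)cc23)cc1` differs from compound 1 by methyl in place of hydrogen on an aromatic carbon. The step that bears on it is a 1.1-fold lower number from compound 1 to compound 2 (0.04 log units; within the scatter), where a small group likewise replaced hydrogen on an aromatic carbon of the anilino ring without moving the number beyond the scatter; an at least 1.0-fold higher number from compound 1 to compound 3 (0.04 log units; that floor lies within the scatter) gives only a floor. The expected step is therefore none beyond the scatter, a 1.0-fold lower number from compound 1 to compound 4 (0.00 log units; within the scatter). Compound 4 is estimated at 45000 nM, in a range from 22000 nM to 90000 nM.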

Compound 4, half-maximal inhibitory concentration: > 50000 nM
Compound 4 gave a limit, no number; the forecaster's own chance of this, stated with the estimate: 30%; middle value at least 1.1-fold (0.04 log units) away from the limit.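

In this assay, methyl para to a large group gives an at least 1.0-fold higher number from compound 1 to compound 4 (0.04 log units; that floor lies within the scatter), and methyl in place of methoxy gives an at least 1.2-fold higher number from compound 2 to compound 4 (0.08 log units; that floor lies within the scatter); both are only floors, so neither step shows a change beyond the scatter. The step between compound 3 and compound 4 cannot be read, as both compounds carry limits. Compound 4 is a second compound at the limit, alongside compound 3: the limit of > 50000 nM in this assay, at which 2 of the 4 values shown sit.

From the compounds shown here alone, whether compound 3 and compound 4 truly differ from compound 1 remains open. Also open, going by these compounds, is whether an amine or a carboxylic acid on this ring would lower the number beyond the scatter.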